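The compounds below may be only part of what the source reports. "The series", "measured", "known", "first", "only" and "open" are said of these compounds alone.

Working notes on the series, all read in a functional assay on HT-29 cells (Homo sapiens) for cytotoxicity, read by MTT assay, with a stated time of 48 h; on this read-out higher numbers stand for weaker inhibition and lower numbers for stronger inhibition. For the measured compounds named here, compound 2 `COC(=O)/C=C/c1ccc2c(c1)C(=O)C(=O)N2Cc1ccccc1` gives 70 nM, the lowest of the three numbers so far. Compound 1 `CCCCOC(=O)/C=C/c1ccc2c(c1)C(=O)C(=O)N2Cc1ccc(OC)cc1` gives 420 nM and compound 3 `COc1ccc(CN2C(=O)C(=O)c3cc(/C=C/C(=O)OCCO)ccc32)cc1` gives 550 nM, and both lie beyond the scatter from compound 2. Next is compound 4 `COC(=O)/C=C/c1ccc2c(c1)C(=O)C(=O)N2C`, with the change (hydrogen in place of phenyl on a saturated chain carbon bound to an amide-type nitrogen in a ring); cut one bond further out, this reads benzyl to methyl. Going by the values given here, no measured step touches this place. Among the compounds with values here, the only step available, a 1.3-fold higher number from compound 1 to compound 3 (0.12 log units; within the scatter), lies elsewhere in the molecule and is within the scatter, so it gives no size to carry over. Compound 1 and compound 3 each differ from compound 2 in more than one place, so their gaps cannot be assigned to any single change. With compound 2 at 70 nM as the lowest number in the set, a move toward a higher number is the likelier direction. The expected step is an 8.6-fold higher number from compound 2 to compound 4 (0.93 log units; beyond the scatter), and its size is poorly constrained. For compound 4 the estimated value is 600 nM, with an expected range from 120 nM to 3000 nM.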

Compound 4, half-maximal inhibitory concentration: 300 nM
Beside the measured number, compound 4's estimate is 2.0-fold (0.30 log units) above it; low and high end bracket the measured number.
By their numbers in this assay, from the lowest: compound 2; then compounds 4, 1 and 3 (each within the scatter of the next).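

In this assay, for the compounds shown here, this is the first measured step at the saturated chain carbon bound to an amide-type nitrogen in a ring: hydrogen in place of phenyl, or benzyl to methyl, gives a 4.3-fold higher number from compound 2 to compound 4 (0.63 log units; beyond the scatter). The step is beyond the scatter, so in this pair the phenyl goes with the lower number, but the step is modest, and compound 4 still gives 300 nM without the aromatic ring. No measurement on hand accounts for the size of this step.

As far as these compounds go, a single pair cannot separate the phenyl ring from the carbon count alone, so it remains open whether a longer chain such as propyl or butyl here would read like benzyl or like methyl. From the compounds shown here alone, it also remains open whether an amine on this chain would shift the number, and whether the step would keep its size with a different ester chain.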